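Dimethylamino to methoxy: working notes on a small series

A few compounds are considered here, and "the series" means these few. Any claim that something is new, unique, unknown or untested is made for them only; others in the source may bear on it.

In a functional assay on A549 cells (Homo sapiens) for inhibition, read by CCK-8 assay, with a stated time of 48 h (a higher number here means a weaker inhibitor, a lower number a stronger inhibitor), three compounds on a shared core have been measured. Compound 1 (`COc1cc(-c2ccnc3cc(-c4ccc(F)cc4)nn23)cc(OC)c1OC`) gives 3800 nM and compound 2 (`COc1cc(-c2ccnc3cc(-c4ccc(C(F)(F)F)cc4)nn23)cc(OC)c1OC`) gives 2070 nM while compound 3 (`COc1cc(-c2ccnc3cc(-c4ccc(N(C)C)cc4)nn23)cc(OC)c1OC`) gives 1100 nM on the same read-out. Compound 3 stands apart from compound 1 (a 3.5-fold lower number from compound 1 to compound 3 (0.54 log units; beyond the scatter)) but is not separated from compound 2 (a 1.9-fold lower number from compound 2 to compound 3 (0.27 log units; within the scatter)). Compound 1 and compound 2 are not separated from each other either (a 1.8-fold lower number from compound 1 to compound 2 (0.26 log units; within the scatter)).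

Compound 4 (`COc1ccc(-c2cc3nccc(-c4cc(OC)c(OC)c(OC)c4)n3n2)cc1`) carries methoxy in place of dimethylamino on an aromatic carbon, para to a large group (methoxy in place of dimethylamino on an aromatic carbon). For the measured compounds named here, no measured compound carries methoxy there, so the evidence is indirect. The two steps into compound 3 change the same group, and both are small (a 3.5-fold lower number from compound 1 to compound 3 (0.54 log units; beyond the scatter) and a 1.9-fold lower number from compound 2 to compound 3 (0.27 log units; within the scatter)). Read backwards, each means a higher number once dimethylamino is gone. The expected step is small and upward (a 1.6-fold higher number from compound 3 to compound 4 (0.21 log units; within the scatter)) and stays within the scatter. Compound 4 is estimated at 1800 nM with an expected range (800 nM to 4000 nM).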

Compound 4, half-maximal inhibitory concentration: 376 nM
The estimate for compound 4 lay 4.8-fold (0.68 log units) above the measured number; the whole stated range lies above it.
By their numbers in this assay, from the lowest: compound 4; then compounds 3, 2 and 1 (each within the scatter of the next, the first and the last beyond it).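

For the compounds shown here, at this position, on an aromatic carbon para to a large group, the earlier compounds showed a single step beyond the scatter, the one from fluoro to dimethylamino, and dimethylamino looked like the best of the groups tried. Methoxy now goes past it in this assay (a 2.9-fold lower number from compound 3 to compound 4 (0.47 log units; beyond the scatter)), although the two groups have the same hydrogen-bond donor and acceptor counts, so those counts do not separate them. Methoxy also stands clear of trifluoromethyl (a 5.5-fold lower number from compound 2 to compound 4 (0.74 log units; beyond the scatter)) and of fluoro (a 10-fold lower number from compound 1 to compound 4 (1.00 log units; beyond the scatter)), which makes compound 4 the strongest inhibitor of the four.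

Nothing available here bears on what lies behind these differences. As far as these compounds go, whether ethoxy, hydroxyl or a longer alkoxy chain at the same place would hold or extend the gain remains open.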